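Adding a Third Methoxy Group to Compound 2

This account rests on a few compounds, and the source may have more. Where it says the series, first, only, none or still open, it means among the compounds named here.

Compound 2 `COc1ccc(/C=C2\CCC/C(=C\c3ccc([N+](=O)[O-])cc3)C2=O)cc1OC` is one of three compounds tested in a functional assay on HSG cells (Homo sapiens) for cytotoxicity (a lower number here means that less compound is tolerated, a higher number that more compound is tolerated), where it gives 13000 nM. Its close relative compound 1 `COc1cc(/C=C2\CCC/C(=C\c3ccc([N+](=O)[O-])cc3)C2=O)ccc1O` gives 11000 nM. The only difference between them is a methyl in place of hydrogen on an oxygen on an aromatic ring, and the step in this assay is a 1.2-fold higher number from compound 1 to compound 2 (0.07 log units; within the scatter). The third compound, compound 3 `COc1ccc(/C=C2\Cc3ccccc3/C(=C\c3ccc([N+](=O)[O-])cc3)C2=O)cc1OC`, carries a different core and gives 4400 nM, which is lower than compound 2 beyond the scatter. Compound 2 thus stands at the high end of the three numbers, though it cannot be separated from compound 1.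

Compound 4 `COc1cc(/C=C2\CCC/C(=C\c3ccc([N+](=O)[O-])cc3)C2=O)cc(OC)c1OC` is not yet measured. It differs from compound 2 by methoxy in place of hydrogen on an aromatic carbon. For the measured compounds named here, no measured step adds a group to an aromatic carbon, so the only related step is the one from compound 1 to compound 2, which changed a group on the same ring and stayed within the scatter. On that basis, the step of no change at the digits printed from compound 2 to compound 4 (within the scatter) is expected to be small, with no clear direction beyond the scatter. Compound 4 is therefore estimated to give 13000 nM in this assay, within a range from 6000 nM to 28000 nM.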

Compound 4, half-maximal cytotoxic concentration: 8300 nM
The estimate for compound 4 lay 1.6-fold (0.19 log units) above the measured number; low and high end bracket the measured number.
By their numbers in this assay, from the lowest: compounds 3, 4, 1 and 2 (each within the scatter of the next, the first and the last beyond it).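

In this assay the new methoxy group, on an aromatic carbon ortho to a methoxy group, meta to a large group and meta to a second methoxy group, gives a 1.6-fold lower number from compound 2 to compound 4 (0.19 log units; within the scatter), so this added group produces no difference that can be told apart from the ordinary spread of repeated measurements. For the compounds shown here, the only earlier step on this ring placed a methyl on an oxygen, whereas this one is the first to replace a hydrogen on an aromatic carbon, and it shows that the ring can carry this further methoxy group without a clear shift in the tolerated concentration. Nothing else is at hand that would explain this result or link it to any property of the added group.

The compounds shown leave open whether a different group on this aromatic carbon, such as an amine or a carboxylic acid, would move the number beyond the scatter. They also leave open whether the same added methoxy group would give a similarly small step on the core of compound 3.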